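Benzyl ring substituents on a shared dimethoxyphenoxy-ethylamine core

A few compounds are considered here, and "the series" means these few. Any claim that something is new, unique, unknown or untested is made for them only; others in the source may bear on it.

Three measured compounds share one core and differ only on the benzyl ring. In an assay on CHO cells for displacement of a labelled ligand from Alpha-1B adrenergic receptor (Homo sapiens) (on this read-out lower numbers stand for stronger inhibition and higher numbers for weaker inhibition), compound 1 `COc1cccc(OC)c1OCCNCCOc1ccccc1OCc1ccccc1` gives 0.537 nM, compound 2 `COc1cccc(OC)c1OCCNCCOc1ccccc1OCc1ccc(Cl)cc1` gives 1 nM and compound 3 `COc1cccc(OC)c1OCCNCCOc1ccccc1OCc1ccccc1C` gives 0.794 nM. Compound 3 sits between the other two numbers, and both of them are within scatter of it: a 1.3-fold lower number from compound 2 to compound 3 (0.10 log units; within the scatter) and a 1.5-fold higher number from compound 1 to compound 3 (0.17 log units; within the scatter). Compound 4 `COc1cccc(OC)c1OCCNCCOc1ccccc1OCc1ccccc1[N+](=O)[O-]` is not yet measured; its change from compound 3 is nitro in place of methyl on an aromatic carbon of a six-membered aromatic ring of carbon only, ortho to a large group.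

Among the measured compounds shown here, the steps that bear on this are the ring substitutions made so far: a 1.5-fold higher number from compound 1 to compound 3 (0.17 log units; within the scatter), which put the methyl in place; a 1.9-fold higher number from compound 1 to compound 2 (0.27 log units; within the scatter), a chloro on the same ring; and a 1.3-fold lower number from compound 2 to compound 3 (0.10 log units; within the scatter). None of the three went beyond the scatter, so the benzyl ring has so far accepted a small group at two places without a shift in this assay. For the measured compounds named here, a nitro has not been tried, and no measured step gives its direction. The estimated step for compound 4 is a 1.4-fold higher number from compound 3 to compound 4 (0.14 log units; within the scatter), with a range that allows for a modest loss. Compound 4 is therefore expected at 1.1 nM, between 0.4 nM and 3 nM.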

Compound 4, inhibition constant: 2.51 nM
Compound 4: middle estimate off by 2.3-fold (0.36 log units), on the low side; measured number inside the range.
By their numbers in this assay, from the lowest: compounds 1, 3 and 2 (each within the scatter of the next); then compound 4.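

In this assay, among the compounds shown here, the nitro is the first change on the benzyl ring to go beyond the scatter: a 3.2-fold higher number from compound 3 to compound 4 (0.50 log units; beyond the scatter) against the methyl, a 4.7-fold higher number from compound 1 to compound 4 (0.67 log units; beyond the scatter) against the unsubstituted ring, and a 2.5-fold higher number from compound 2 to compound 4 (0.40 log units; beyond the scatter) against the 4-chlorophenyl compound. This position, on an aromatic carbon ortho to a large group, therefore does not accept every group alike: the methyl stays within the scatter of hydrogen, whereas the nitro moves the number clear of all three earlier compounds, though each step is only modest and compound 4 still reads 2.51 nM in this assay. Nothing available explains why the nitro behaves differently from the methyl here.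

From the compounds shown here alone, whether an amine, a methoxy or a carboxylic acid at this position would stay with the methyl or follow the nitro remains open. Among the compounds shown, the nitro stands at this one place only, so the step from the 4-chlorophenyl compound changes group and place together, and the two contributions cannot be separated.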